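Phenylpiperazine Amide as the Next Step in MCF7 Cytotoxicity

The source may hold more compounds than are shown below. What is called first, only, known or untested is meant among the compounds shown, and "the series" means these compounds.

Three amides on a shared core have been measured in a functional assay on MCF7 cells (Homo sapiens) for cytotoxicity, read by MTT assay, with a stated time of 24 h, tested at 16 ug/mL; a higher number here means a stronger effect of the compound at the concentration tested, a lower number a weaker effect. Compound 1 `Cc1ccc2oc(SCC(=O)Nc3ccc(-c4nc(-c5ccccc5)c(-c5ccccc5)n4C)cc3)nc2c1` gives 40.3%. Compound 2 `CN1CCN(CC(=O)Nc2ccc(-c3nc(-c4ccccc4)c(-c4ccccc4)n3C)cc2)CC1` gives 30.1%, and compound 3 `CN(C)/C=C/N1CCN(CC(=O)Nc2ccc(-c3nc(-c4ccccc4)c(-c4ccccc4)n3C)cc2)CC1` gives 19.4%. Compound 3 therefore stands lowest of the three: the nearest is compound 2 with a number 10.7 percentage points lower from compound 2 to compound 3 (beyond the scatter), the furthest compound 1 with a number 20.9 percentage points lower from compound 1 to compound 3 (beyond the scatter).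

The step to compound 4 `Cn1c(-c2ccc(NC(=O)CN3CCN(c4ccccc4)CC3)cc2)nc(-c2ccccc2)c1-c1ccccc1` is phenyl in place of 2-(dimethylamino)ethenyl on an amine nitrogen in a ring. The closest measured steps are those that alter the group on the ring nitrogen: a number 10.7 percentage points lower from compound 2 to compound 3 (beyond the scatter), and a number 10.2 percentage points lower from compound 1 to compound 2 (beyond the scatter), which together place the 2-(dimethylamino)ethenyl substituent at the bottom and the (5-methyl-1,3-benzoxazol-2-yl)sulfanyl compound at the top. For the measured compounds named here, a phenyl on the amine nitrogen in a ring has no direct precedent here, so the size of the step is uncertain; a modest rise toward the level of compound 2 is expected, as a number 11.6 percentage points higher from compound 3 to compound 4 (beyond the scatter). Compound 4 is estimated at 31%, within a range from 17% to 46%.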

Compound 4, a percentage reported as activity, at one concentration (the size of the read-out at that concentration, not a potency): 59.6%
Estimate against measurement, compound 4: 28.6 percentage points below; the measured number lies above the stated range.
By their numbers in this assay, from the lowest: compound 3; then compound 2; then compound 1; then compound 4.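

On the amine nitrogen in a ring, the earlier compounds had shown a change only lowering the number, while phenyl now raises it in this assay, with a number 29.5 percentage points higher from compound 2 to compound 4 (beyond the scatter) against methyl and a number 40.2 percentage points higher from compound 3 to compound 4 (beyond the scatter) against 2-(dimethylamino)ethenyl . The 4-phenylpiperazin-1-yl group also overtakes (5-methyl-1,3-benzoxazol-2-yl)sulfanyl, with a number 19.3 percentage points higher from compound 1 to compound 4 (beyond the scatter), which makes compound 4 the strongest of the four at the concentration tested and moves the top of the series to a piperazine amide. No measured evidence accounts for this rise.

As far as these compounds go, whether the gain needs an aromatic ring directly on this nitrogen stays open, since a benzyl or cyclohexyl group there would be needed to tell. From the compounds shown here alone, how substituents on the phenyl ring, such as a methoxy group or a chlorine, would alter the number is also open.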